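Chloro for fluoro on the anilide ring of compound 3

This account rests on a few compounds, and the source may have more. Where it says the series, first, only, none or still open, it means among the compounds named here.

Measured so far in a functional assay on HT-29 cells (Homo sapiens) for cytotoxicity, read by MTT assay, with a stated time of 72 h; on this read-out higher numbers stand for weaker inhibition and lower numbers for stronger inhibition:
compound 1, `O=C(CN1CCN(c2nnc(Cc3ccncc3)c3ccccc23)CC1)Nc1ccc(F)c(F)c1`, gives 2320 nM;
compound 2, `COc1ccc(NC(=O)CN2CCN(c3nnc(Cc4ccccc4)c4ccccc34)CC2)cc1OC`, gives 145000 nM;
compound 3, `O=C(CN1CCN(c2nnc(Cc3ccccc3)c3ccccc23)CC1)Nc1ccc(F)c(F)c1`, gives 9510 nM.

Compound 3 holds the second highest of these three numbers. Its nearest neighbour is compound 1, and the step of a 4.1-fold higher number from compound 1 to compound 3 (0.61 log units; beyond the scatter) is modest. The furthest is compound 2, and the step of a 15-fold lower number from compound 2 to compound 3 (1.18 log units; beyond the scatter) is large.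

Compound 4, `O=C(CN1CCN(c2nnc(Cc3ccccc3)c3ccccc23)CC1)Nc1ccc(F)c(Cl)c1`, is the next step from compound 3. The change is chloro in place of fluoro on an aromatic carbon.

For the measured compounds named here, no measured step swaps one halogen for another, so none bears on this change directly. The step of a 15-fold lower number from compound 2 to compound 3 (1.18 log units; beyond the scatter) shows that the group on the amide-type nitrogen can move the number a long way, but it compares 3,4-dimethoxyphenyl with 3,4-difluorophenyl, not chloro with fluoro. The step of a 4.1-fold higher number from compound 1 to compound 3 (0.61 log units; beyond the scatter) concerns the other end of the molecule and says nothing about this ring. On that basis a change no larger than the scatter, or a small lowering, is expected in this assay for compound 4, and the expected step is a 1.6-fold lower number from compound 3 to compound 4 (0.20 log units; within the scatter). The estimate for compound 4 is 6000 nM, within the range 2000 nM to 18000 nM.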

Compound 4, half-maximal inhibitory concentration: 13300 nM
Beside the measured number, compound 4's estimate is 2.2-fold (0.35 log units) below it; low and high end bracket the measured number.
By their numbers in this assay, from the lowest: compound 1; then compounds 3 and 4 (each within the scatter of the next); then compound 2.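

In this assay, the step of a 1.4-fold higher number from compound 3 to compound 4 (0.15 log units; within the scatter) shows that chloro and fluoro cannot be told apart at this place, on an aromatic carbon ortho to a fluoro group and meta to a large group. For the compounds shown here, the earlier compounds showed only that the group on the amide-type nitrogen can matter a great deal; this pair shows that a single halogen exchange on that ring need not. The step of an 11-fold lower number from compound 2 to compound 4 (1.04 log units; beyond the scatter) is large, so 3-chloro-4-fluorophenyl, like 3,4-difluorophenyl, stands well apart from 3,4-dimethoxyphenyl, and that separation does not rest on one particular halogen at this place; no measurement at hand explains this result.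

What the compounds shown leave open is how far this tolerance extends, for instance to bromo, methyl or an amino group at the same place, since only chloro and fluoro can be compared there. Going by these compounds, it is also open whether the 3-chloro-4-fluorophenyl group would read the same when the phenyl on the saturated chain carbon is replaced by the pyridin-4-yl of compound 1.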